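A Ring Nitrogen Enters the Hydroxyethoxy Arm

The source may hold more compounds than are shown below. What is called first, only, known or untested is meant among the compounds shown, and "the series" means these compounds.

Of the compounds shown here, three sharing one core have been tested in a functional assay on A549 cells (Homo sapiens) for antiproliferative activity, read by sulforhodamine B assay, with a stated time of 72 h; a lower number here means a stronger inhibitor, a higher number a weaker inhibitor. Compound 1, `COc1ncc(-c2ccc3ncnc(Nc4ccc(OCCO)cc4)c3c2)cc1NS(C)(=O)=O`, gives 5200 nM. Compound 2, `COc1ncc(-c2ccc3ncnc(Nc4ccc(OCCO)c(F)c4)c3c2)cc1NS(=O)(=O)c1ccc(F)cc1F`, gives 6640 nM, and compound 3, `COc1ncc(-c2ccc3ncnc(Nc4cnn(CC(=O)O)c4)c3c2)cc1NS(=O)(=O)c1ccc(F)cc1F`, gives 5200 nM. Among the compounds with values here, the only single-point comparison among them is a 1.3-fold lower number from compound 2 to compound 3 (0.11 log units; within the scatter), a change of the whole group on a nitrogen on an aromatic ring that did not move the number beyond the scatter. Compound 1 stands level with compound 3, and its gap to compound 2 also lies within the scatter, so the three numbers are effectively alike.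

Compound 4, `COc1ncc(-c2ccc3ncnc(Nc4ccc(OCCO)nc4)c3c2)cc1NS(C)(=O)=O`, differs from compound 1 in one place: 6-(2-hydroxyethoxy)pyridin-3-yl in place of 4-(2-hydroxyethoxy)phenyl on a nitrogen on an aromatic ring. Within the data shown here, no measured step bears directly on this change, since the pair from compound 2 to compound 3 swaps an entirely different group at that nitrogen and is the one step available. All the evidence gathered so far says that variation at this position leaves the read-out within the scatter.

Compound 4 is therefore expected to give about 5200 nM, with a likely range from 2500 nM to 11000 nM. The expected step of no change at the digits printed from compound 1 to compound 4 (within the scatter) is estimated to be none beyond the scatter.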

Compound 4, half-maximal inhibitory concentration: 5080 nM
For compound 4 the middle estimate is 1.0-fold (0.01 log units) above the measured one; measured number inside the range.
By their numbers in this assay, from the lowest: compounds 4, 1, 3 and 2 (each within the scatter of the next).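

Before this, the only step at this nitrogen replaced one whole group with a very different one. Here the 2-hydroxyethoxy arm stays and only the ring changes, from carbon-only to one with a ring nitrogen, and in this assay the result is a 1.0-fold lower number from compound 1 to compound 4 (0.01 log units; within the scatter). With the rest of compound 1 held fixed, this position therefore accepts a pyridine ring in place of a phenyl ring, and the entering group's count of 3 hydrogen-bond acceptors against 2 brings no readable difference in the number. Nothing measured here explains why the number holds steady.

As far as these compounds go, the four compounds sit within the scatter of one another when taken in order of their numbers, so it remains open whether any change at this nitrogen can shift the read-out, for instance an amine in place of the hydroxyl of the arm, or a longer chain carrying it. From the compounds shown here alone, it is also open whether the same ring nitrogen would behave alike when paired with the fluorinated sulfonamide group of compound 2 and compound 3.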